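Bromo in Place of Hydrogen: Cytotoxicity Outlook on the Core

This account rests on a few compounds, and the source may have more. Where it says the series, first, only, none or still open, it means among the compounds named here.

Compound 1 `NC(=O)c1nccn([C@@H]2O[C@H](CO)[C@@H](O)[C@H]2O)c1=O` is the parent of the pair followed here. In an ADME assay on MDCK cells (Canis lupus familiaris) for cytotoxicity, read by microscopy, with a stated time of 3 days (a lower number here means that less compound is tolerated, a higher number that more compound is tolerated), compound 1 gives > 250000 nM, which is a limit of the assay and not a number. Compound 1 thus sits at the limit of > 250000 nM in this assay, at which 1 of the 2 values shown sits, on the well-tolerated side of the series. Going by the values given here, compound 2 `CCCCCCCCCCCCCCC(=O)Oc1ccc(COP(=O)(OCc2ccc(OC(=O)CCCC)cc2)OP(=O)(O)OC[C@H]2O[C@@H](n3cc(F)nc(C(N)=O)c3=O)[C@H](O)[C@@H]2O)cc1` is a much larger structure with no defined step to compound 1 or compound 3; in this assay compound 2 gives 16000 nM. Compound 3 `NC(=O)c1nc(Br)cn([C@@H]2O[C@H](CO)[C@@H](O)[C@H]2O)c1=O` is not yet measured. It differs from compound 1 by bromo in place of hydrogen on an aromatic carbon. Among the compounds with values here, no measured step covers this change, so nothing in the data points either way. The step from compound 1 to compound 3 in this assay is expected to be an at least 1.6-fold lower number from compound 1 to compound 3 (0.22 log units; that floor lies within the scatter), that is, none beyond the scatter, with a limit again a likely outcome. Compound 3 is estimated at 150000 nM, with a range from 30000 nM to 250000 nM.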

Compound 3, minimum cytotoxic concentration: > 250000 nM
Compound 3: only a limit was reported; the forecaster's own chance of this, stated with the estimate: 50%; middle value at least 1.6-fold (0.22 log units) from the limit.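

In this assay, going by these compounds alone, compound 3 gives > 250000 nM, a limit of the assay and not a number, so no step between compound 1 and compound 3 can be read, both resting on a limit: the limit of > 250000 nM in this assay, at which 2 of the 3 values shown sit. Going by these compounds, whether bromo in place of hydrogen shifts the minimum cytotoxic concentration at all stays open.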